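Methyl on the ring carbon: clearance notes

The source may hold more compounds than are shown below. What is called first, only, known or untested is meant among the compounds shown, and "the series" means these compounds.

Measured in an ADME assay on the whole organism (Rattus norvegicus, strain Sprague-Dawley) for pharmacokinetics, using cassette dosing, at a dose of 0.5 mg/kg by the intravenous route; a lower number here means slower removal, a higher number faster removal of the compound:
- compound 1 `O=C(Nc1ccc2[nH]c(=O)oc2c1)C(=O)N1CCN(c2ccc(F)cc2)CC1`: 11.1 mL/min/kg
- compound 2 `O=C(Nc1ccc2[nH]c(=O)oc2c1)C(=O)N1CCN(c2ccc(Cl)c(F)c2)CC1`: 5.6 mL/min/kg

Compound 2 at 5.6 mL/min/kg stands within the scatter of compound 1 at 11.1 mL/min/kg, so the two numbers do not separate the compounds. Among the measured compounds shown here, they are the only reference points so far.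

The next compound is compound 3 `C[C@@H]1CN(C(=O)C(=O)Nc2ccc3[nH]c(=O)oc3c2)CCN1c1ccc(Cl)c(F)c1`, which has methyl in place of hydrogen on a saturated ring carbon. The aryl group and the shared core stay as they are in compound 2.

For the measured compounds named here, only one measured step is available, a 2.0-fold lower number from compound 1 to compound 2 (0.30 log units; within the scatter), and it lies within the scatter. That step concerns the aryl group on the ring nitrogen, not the ring carbon, so it bears on the new change only indirectly. Going by the values given here, no measured compound carries a substituent on that ring carbon, and the data therefore give no direction for this change. No shift beyond the scatter is expected in this assay.

The expected step is a 1.2-fold higher number from compound 2 to compound 3 (0.06 log units; within the scatter).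

For compound 3 the estimated clearance is 6.5 mL/min/kg, with an expected range of 3 mL/min/kg to 14 mL/min/kg.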

Compound 3, clearance: 6 mL/min/kg
For compound 3 the middle estimate is 1.1-fold (0.03 log units) above the measured one; low and high end bracket the measured number.
By their numbers in this assay, from the lowest: compounds 2, 3 and 1 (each within the scatter of the next).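

In this assay, methyl in place of hydrogen on a saturated ring carbon gives a 1.1-fold higher number from compound 2 to compound 3 (0.03 log units; within the scatter), so this readout does not separate compound 3 from compound 2. Among the compounds shown here, until now, this carbon carried only hydrogen in the measured compounds; compound 3 provides the first reading with a substituent there, on the ring carbon next to the ring atom that bears the 4-chloro-3-fluorophenyl group, and that reading stays within the scatter of its parent. Nothing on hand accounts for this result or tells what, if anything, the methyl does in the animal.

Going by these compounds, whether a larger group or one of another kind on this carbon, such as ethyl, hydroxymethyl or an amine, would stay within the scatter of compound 2 remains open, as does the opposite spatial arrangement of the methyl. The compounds shown also leave open whether the methyl gives a comparable reading with the 4-fluorophenyl group of compound 1, since the only reading at this carbon comes with the 4-chloro-3-fluorophenyl group.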